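The source may report more compounds than this note shows. Statements on the series, on what has been measured and on what is new or still open speak of the compounds shown alone.

Notes on the series, read in an in vitro ADME assay on microsomes from liver (Homo sapiens) for metabolic stability; on this read-out lower numbers stand for slow clearance and higher numbers for fast clearance: compound 1 `COC(=O)[C@H]1CC[C@@H](n2/c(=N/C(=O)c3ccccc3)[nH]c3ccc(CN4CCCCC4)cc32)CC1` gives 85 mL.min-1.g-1 and compound 2 `CC(C)NC(=O)[C@H]1CC[C@@H](n2/c(=N/C(=O)c3ccccc3)[nH]c3ccc(CN4CCCCC4)cc32)CC1` gives 203 mL.min-1.g-1, so compound 2 holds the higher of the two numbers available. The next structure is compound 3 `CCNC(=O)[C@H]1CC[C@@H](n2/c(=N/C(=O)c3ccccc3)[nH]c3ccc(CN4CCCCC4)cc32)CC1`. It differs from compound 2 by hydrogen in place of methyl on a saturated chain carbon bound to an amide-type nitrogen and a saturated chain carbon, which turns isopropylcarbamoyl into ethylcarbamoyl.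

For the measured compounds named here, only one measured step bears on this, and only indirectly: a 2.4-fold higher number from compound 1 to compound 2 (0.38 log units; beyond the scatter), a modest step with isopropylamino in place of methoxy on a carbonyl carbon. That step exchanges the whole group on the carbonyl carbon, whereas the new change only shortens isopropyl to ethyl. Going by the values given here, no measured pair isolates such a shortening, so its size and direction remain open. Taking ethylamino as a smaller move along the same line, a small shift towards the lower number is expected, one that may not clear the usual scatter. The expected step is a 1.4-fold lower number from compound 2 to compound 3 (0.13 log units; within the scatter). For compound 3 the estimate is 150 mL.min-1.g-1, with an expected range of 85 mL.min-1.g-1 to 260 mL.min-1.g-1.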

Compound 3, intrinsic clearance in microsomes: 194 mL.min-1.g-1
For compound 3 the middle estimate is 1.3-fold (0.11 log units) below the measured one; low and high end bracket the measured number.
By their numbers in this assay, from the lowest: compound 1; then compounds 3 and 2 (each within the scatter of the next).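

In this assay, cutting isopropylcarbamoyl back to ethylcarbamoyl gives a 1.0-fold lower number from compound 2 to compound 3 (0.02 log units; within the scatter) and so compound 2 and compound 3 cannot be told apart; at this position the loss of that one methyl leaves no readable mark on the read-out. Ethylamino in place of methoxy on the carbonyl carbon gives a 2.3-fold higher number from compound 1 to compound 3 (0.36 log units; beyond the scatter) and this sits beside a 2.4-fold higher number from compound 1 to compound 2 (0.38 log units; beyond the scatter) as a second step beyond the scatter, so the gap from compound 1 is not tied to isopropylamino alone and holds for both amides shown, with no compound here going against it. Nothing measured here gives a cause for either step.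

Still open, on these data alone, is how far this insensitivity to the alkyl group reaches: methylamino, an unsubstituted carbamoyl or a longer chain such as butylamino on the same carbonyl carbon would test it, and a carboxylic acid in place of the methyl ester would extend the comparison with compound 1. Equally open, as far as these compounds go, is whether a tertiary amide such as dimethylcarbamoyl, without the amide hydrogen, would read with compound 2 and compound 3 or with compound 1.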